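The source may report more compounds than this note shows. Statements on the series, on what has been measured and on what is new or still open speak of the compounds shown alone.

Compound 2 `CC(=O)c1cc(CC(C)O)c(OCCCCC#N)cc1O` stands lowest of the two measured compounds: in an assay on isolated protein for inhibition of leukotriene B4 receptor 1 (Homo sapiens), tested at 10 uM (on this read-out higher numbers stand for more inhibition at the one concentration tested (going by the name of the read-out) and lower numbers for less inhibition), compound 2 gives 10%, whereas compound 1 `CCCCCc1cc(C(C)=O)c(O)cc1OCCCCC#N` gives 31%. Compound 3 `CC(=O)c1cc(C(C)=O)c(OCCCCC#N)cc1O` differs from compound 2 by acetyl in place of 2-hydroxypropyl on an aromatic carbon. Within the data shown here, the only measured step, a number 21 percentage points lower from compound 1 to compound 2 (beyond the scatter), altered the same side chain, though not in the same way, so it bears only loosely on this change. With the 2-hydroxypropyl group leaving, a modest rise is expected, a number 10 percentage points higher from compound 2 to compound 3 (within the scatter). Compound 3 is therefore estimated at 20%, within a range from 5% to 40%.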

Compound 3, a percentage reported as inhibition, at one concentration (the size of the read-out at that concentration, not a potency): 8%
Compound 3: the middle estimate sits 12 percentage points above what was measured; measured number inside the range.
By their numbers in this assay, from the lowest: compounds 3 and 2 (each within the scatter of the next); then compound 1.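

In this assay, acetyl in place of 2-hydroxypropyl on this aromatic carbon makes no clear difference, a number 2 percentage points lower from compound 2 to compound 3 (within the scatter). Acetyl in place of pentyl, by contrast, gives a number 23 percentage points lower from compound 1 to compound 3 (beyond the scatter), so at this position compound 1 with its pentyl chain stands clear of both compound 2 and compound 3, which cannot be told apart. No measurement at hand accounts for why the pentyl chain stands apart. Going by these compounds, whether a longer chain than pentyl would give more inhibition here stays open, as does what an amine or a carboxylic acid at this position would give.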